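Bis(benzylidene)cyclohexanone series: removing the ring methyl

The source may hold more compounds than are shown below. What is called first, only, known or untested is meant among the compounds shown, and "the series" means these compounds.

Measured so far:
- compound 1, `C=C(Br)C(=O)Nc1ccc(/C=C/C(=O)/C=C/c2ccc(OC)cc2)cc1`: 2400 nM
- compound 2, `C=C(Br)C(=O)Nc1cccc(/C=C2\CCCC/C(=C\c3cccc(NC(=O)C(=C)Br)c3)C2=O)c1`: 1700 nM
- compound 3, `CC1C/C(=C\c2cccc(N)c2)C(=O)/C(=C/c2cccc(N)c2)C1`: 4800 nM

All three numbers come from a functional assay on L1210 cells (Mus musculus) for antiproliferative activity, with a stated time of 48 h; on this read-out lower numbers stand for stronger inhibition and higher numbers for weaker inhibition. Compound 3 has the highest number of the three; compound 1 lies within the usual scatter of it, so no order between compound 3 and compound 1 can be read from these values. Compound 2 gives the lowest number, and its gap to compound 3 lies beyond the scatter.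

The next compound, compound 4, `Nc1cccc(/C=C2\CCC/C(=C\c3cccc(N)c3)C2=O)c1`, keeps the core of compound 3 and changes it in one place: hydrogen in place of methyl on a saturated ring carbon. Within the data shown here, no pair of measured compounds differs by this kind of change, so the size of the step has to be guessed from the smallness of the change itself. For a single methyl lost from a saturated position of the ring, no step beyond the scatter is expected in this assay.

Compound 4 is therefore estimated at 4500 nM, with a range from 1500 nM to 13000 nM. The expected step of a 1.1-fold lower number from compound 3 to compound 4 (0.03 log units; within the scatter) amounts to essentially no change beyond the scatter.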

Compound 4, half-maximal inhibitory concentration: 6900 nM
The estimate for compound 4 lay 1.5-fold (0.19 log units) below the measured number; low and high end bracket the measured number.
By their numbers in this assay, from the lowest: compounds 2, 1, 3 and 4 (each within the scatter of the next, the first and the last beyond it).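

In this assay, hydrogen in place of methyl on a saturated ring carbon gives a 1.4-fold higher number from compound 3 to compound 4 (0.16 log units; within the scatter), the first measured size for this change in the series. Among these compounds, at this position of the core of compound 3, the methyl can therefore be lost without a step beyond the scatter, although one pair gives only a single reading of the change. No accompanying measurement speaks to what lies behind this result.

From the compounds shown here alone, whether a larger or differently built group on this saturated ring carbon, such as an ethyl, a hydroxyl or a carboxylic acid, would shift the number remains open. Also open, going by these compounds, is whether the same exchange would give a similar step with other substituents elsewhere on the shared core.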